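This account rests on a few compounds, and the source may have more. Where it says the series, first, only, none or still open, it means among the compounds named here.

Compound 1 `O=C(/C=C/c1ccc2c(c1)B(O)OC2)c1cccs1` — in a functional assay on SK-OV-3 cells (Homo sapiens) for cytotoxicity, read by MTT assay, with a stated time of 48 h (on this read-out higher numbers stand for weaker inhibition and lower numbers for stronger inhibition), compound 1 gives 10400 nM.
Compound 2 `O=C(/C=C/c1ccc2c(c1)B(O)OC2)c1ccc(O)cc1` — in this assay compound 2 gives 13000 nM.

On the two numbers shown, compound 2 stands alongside compound 1: the only measured step, a 1.3-fold higher number from compound 1 to compound 2 (0.10 log units; within the scatter), lies within the scatter, so neither compound can be set apart from the other in this assay. Compound 3 `O=C(/C=C/c1ccc2c(c1)B(O)OC2)c1cccc(F)c1` has not yet been measured. It differs from compound 2 by 3-fluorophenyl in place of 4-hydroxyphenyl on a carbonyl carbon. For the measured compounds named here, the one step that bears on this change is the exchange of groups on the same carbonyl carbon, a 1.3-fold higher number from compound 1 to compound 2 (0.10 log units; within the scatter), which was within the scatter; no measured step exchanges the 4-hydroxyphenyl for a 3-fluorophenyl. On that basis the number for compound 3 in this assay is expected to move by a 1.2-fold lower number from compound 2 to compound 3 (0.07 log units; within the scatter), that is, not beyond the scatter. Compound 3 is therefore estimated at 11000 nM, with a range from 4000 nM to 30000 nM.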

Compound 3, half-maximal inhibitory concentration: 4800 nM
Compound 3: the middle estimate sits 2.3-fold (0.36 log units) above what was measured; low and high end bracket the measured number.
By their numbers in this assay, from the lowest: compound 3; then compounds 1 and 2 (each within the scatter of the next).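

The 3-fluorophenyl group gives a 2.7-fold lower number from compound 2 to compound 3 (0.43 log units; beyond the scatter) against 4-hydroxyphenyl and a 2.2-fold lower number from compound 1 to compound 3 (0.34 log units; beyond the scatter) against thiophen-2-yl on the same carbonyl carbon, so in this assay the group at this place can shift the number, if only modestly. For the compounds shown here, the earlier pair of 4-hydroxyphenyl and thiophen-2-yl could not show this, as those two groups stay within the scatter of each other, and 3-fluorophenyl is the only group here set apart from both. No evidence is available to explain this shift.

The compounds shown do not tell whether the shift follows from the fluorine itself or from the phenyl ring carrying no hydroxyl, a question that a plain phenyl or a chlorophenyl group at this place would bear on. Since all three compounds keep the shared core, they also leave open how any change outside this place would read.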